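This account rests on a few compounds, and the source may have more. Where it says the series, first, only, none or still open, it means among the compounds named here.

Three analogues sharing one core were tested in a functional assay on PC-3 cells (Homo sapiens) for antiproliferative activity, read by MTT assay, with a stated time of 72 h; a higher number here means a weaker inhibitor, a lower number a stronger inhibitor. Compound 1 `CCCSc1nc(Cl)c2c(n1)N(Cc1ccccc1)C(C(=O)N1CCN(Cc3ccccc3)CC1)N2` gives 57300 nM there. Compound 2 `CCCSc1nc(Cl)c2c(n1)N(Cc1cccs1)C(C(=O)N1CCN(C)CC1)N2` gives 5020 nM in this assay. Compound 3 `CCCSc1nc(Cl)c2c(n1)N(Cc1ccccc1)C(C(=O)NCCC1=CCc3ccccc31)N2` reaches only the limit of this assay, > 64000 nM, which is not a number but the edge of what the assay reports (the limit of > 64000 nM in this assay, at which 1 of the 3 values shown sits). Compound 4 `CCCSc1nc(Cl)c2c(n1)N(Cc1ccccc1)C(C(=O)NCC(C)C)N2` differs from compound 3 by a group of 3 heavy atoms (3 carbon; no ring) in place of a group of 10 heavy atoms (10 carbon; one five-membered non-aromatic ring of carbon only, one six-membered aromatic ring of carbon only), on a saturated chain carbon bound to an amide-type nitrogen. For the measured compounds named here, no measured pair isolates this change, and compound 3 itself offers only a limit, so the direction is open. The expected step of an at least 1.4-fold lower number from compound 3 to compound 4 (0.15 log units; that floor lies within the scatter) is a modest gain in potency, without confidence beyond the scatter. Compound 4 is therefore estimated at 45000 nM, with a likely range from 12000 nM to 160000 nM.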

Compound 4, half-maximal inhibitory concentration: > 64000 nM
Compound 4 was reported as a limit (the forecaster's own chance of this, stated with the estimate: 40%); middle value at least 1.4-fold (0.15 log units) away from the limit.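

No step can be read between compound 3 and compound 4, as both stand only as limits in this assay: the limit of > 64000 nM in this assay, at which 2 of the 4 values shown sit.

The compounds shown leave open whether swapping the larger group for isopropyl changes potency at all.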